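Series notes: from compound 1 to compound 4

The compounds below may be only part of what the source reports. "The series", "measured", "known", "first", "only" and "open" are said of these compounds alone.

Compound 1 `O=C(NC(=S)Nc1nc2ccccc2s1)c1ccc([N+](=O)[O-])cc1` is tested in a functional assay on HeLa cells (Homo sapiens) for cytotoxicity, read by MTT assay, with a stated time of 24 h (on this read-out lower numbers stand for stronger inhibition and higher numbers for weaker inhibition), where compound 1 gives 62600 nM. Compound 2 `Nc1ccc2sc(NC(=S)NC(=O)N3CCOCC3)nc2c1` gives 45300 nM and compound 3 `O=C(NC(=S)Nc1nc2ccccc2s1)N1CCOCC1` gives 51800 nM; the gaps from compound 1 to both lie within the scatter, so the three numbers stand together. Going by the values given here, the only single-point step measured so far is a 1.1-fold higher number from compound 2 to compound 3 (0.06 log units; within the scatter), and it bears on compound 4 only loosely, as a change on an aromatic carbon of the shared core. Compound 4 `O=C(NC(=S)Nc1nc2cc([N+](=O)[O-])ccc2s1)c1ccc([N+](=O)[O-])cc1` differs from compound 1 by nitro in place of hydrogen on an aromatic carbon. Among the compounds with values here, no measured step introduces a nitro group there, so no step beyond the scatter is expected, and a 1.0-fold lower number from compound 1 to compound 4 (0.02 log units; within the scatter) is the estimated change. Compound 4 is therefore expected near 60000 nM, within 25000 nM to 150000 nM.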

Compound 4, half-maximal inhibitory concentration: 68500 nM
The estimate for compound 4 lay 1.1-fold (0.06 log units) below the measured number; measured number inside the range.
By their numbers in this assay, from the lowest: compounds 2, 3, 1 and 4 (each within the scatter of the next).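

Nitro in place of hydrogen on this aromatic carbon of the shared core gives a 1.1-fold higher number from compound 1 to compound 4 (0.04 log units; within the scatter), so in this assay the position carries this group with no step beyond the scatter. The earlier step read only amino on an aromatic carbon of the core, with a different remainder of the molecule, and it too stayed within the scatter. No evidence at hand bears on the reason for this result. As far as these compounds go, whether a carboxylic acid or a longer chain at this position would also leave the number within the scatter remains open, as does the effect of nitro on the other aromatic carbons of the core.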